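Working notes on compound 3 and compound 4

The compounds below may be only part of what the source reports. "The series", "measured", "known", "first", "only" and "open" are said of these compounds alone.

Measured in a functional assay on MGC-803 cells (Homo sapiens) for inhibition, read by MTT assay, with a stated time of 72 h; on this read-out lower numbers stand for stronger inhibition and higher numbers for weaker inhibition:
compound 1 `CCc1cccc(NC(=O)CSc2nc(Nc3ccccc3)c3ccccc3n2)c1`: 15800 nM
compound 2 `CCc1ccc(NC(=O)CSc2nc(Nc3ccccc3)c3ccccc3n2)cc1`: > 50000 nM, a limit of the assay
compound 3 `C=CC(=O)Nc1cccc(NC(=O)CSc2nc(Nc3ccccc3Cl)c3ccccc3n2)c1`: 20700 nM

Compound 3 has the highest of the two numbers given, and compound 1 sits within the scatter of it. Compound 2 gives only a limit. One step among the measured compounds is known: an at least 3.1-fold higher number from compound 1 to compound 2 (0.50 log units; beyond the scatter); it concerns the amide-type nitrogen, a different place from the change considered here, with the limit of > 50000 nM in this assay, at which 1 of the 3 values shown sits, showing one value at the limit. Compound 4 `C=CC(=O)Nc1cccc(NC(=O)CSc2nc(Nc3ccc(C(F)(F)F)cc3)c3ccccc3n2)c1` differs from compound 3 in one place: 4-(trifluoromethyl)phenyl in place of 2-chlorophenyl on a nitrogen on an aromatic ring. For the measured compounds named here, no measured step touches this position, so no step beyond the scatter is expected in this assay, in either direction. For compound 4 the expected value is 25000 nM, range 8000 nM to 60000 nM, which means an expected step of a 1.2-fold higher number from compound 3 to compound 4 (0.08 log units; within the scatter).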

Compound 4, half-maximal inhibitory concentration: 12100 nM
Compound 4: the middle estimate sits 2.1-fold (0.32 log units) above what was measured; the measured number falls inside the stated range.
By their numbers in this assay, from the lowest: compounds 4, 1 and 3 (each within the scatter of the next). At a limit, above all of these: compound 2.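

In this assay this position, on a nitrogen on an aromatic ring, now has its first readable step, a 1.7-fold lower number from compound 3 to compound 4 (0.23 log units; within the scatter), so 2-chlorophenyl and 4-(trifluoromethyl)phenyl are not told apart here. This single pair shows that the position accepts either group without a step beyond the scatter. Nothing shown bears on the reason for this result. Open, from the compounds shown here alone, is how a ring carrying an amine or a carboxylic acid would read at this position. Also open, going by these compounds, is whether this pair reads alike on other cell lines.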